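The source may hold more compounds than are shown below. What is called first, only, known or untested is meant among the compounds shown, and "the series" means these compounds.

Measured in a functional assay on K562 cells (Homo sapiens), read by MTT assay, with a stated time of 72 h; on this read-out higher numbers stand for weaker inhibition and lower numbers for stronger inhibition:

Compound 1 `COc1ncnc2c1c(-c1ccccc1)cn2[C@@H]1O[C@H](CO)[C@@H](O)[C@H]1O`: > 20000 nM
Compound 2 `CSc1ncnc2c1c(-c1cccs1)cn2[C@@H]1O[C@H](CO)[C@@H](O)[C@H]1O`: > 20000 nM

Neither entry is a number. Compound 2 stands at a limit of the assay, > 20000 nM, and gives no measured potency. Across the pair, the data show only (the limit of > 20000 nM in this assay, at which 2 of the 2 values shown sit). Compound 3 `C#Cc1cn([C@@H]2O[C@H](CO)[C@@H](O)[C@H]2O)c2ncnc(SC)c12` keeps the core of compound 2 and carries ethynyl in place of thiophen-2-yl on an aromatic carbon. For the measured compounds named here, no measured step shows what such a change does in this assay, so any forecast is loose. A move towards stronger inhibition is expected, of moderate size, though the result could remain at the limit. The expected change is an at least 3.3-fold lower number from compound 2 to compound 3 (0.52 log units; beyond the scatter). The estimated value for compound 3 is 6000 nM. The expected range runs from 500 nM to 20000 nM.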

Compound 3, half-maximal inhibitory concentration: 70 nM
Estimate against measurement, compound 3: 86-fold (1.93 log units) above; measured number outside the range, below it.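

Two of the three compounds shown give no number in this assay, only a limit: the limit of > 20000 nM in this assay, at which 2 of the 3 values shown sit.

Compound 3 holds the only measured potency here, so this aromatic carbon of the five-membered aromatic ring can carry a group that gives clear inhibition of K562 cells. Ethynyl in place of thiophen-2-yl gives an at least 280-fold lower number from compound 2 to compound 3 (2.45 log units; beyond the scatter), a large step beyond the scatter, and its true size stays unknown as it starts from a limit. This is a single pair, so it shows what this one change does and sets no trend for the position.

The compounds shown leave open whether the triple bond itself matters or whether another small group, such as ethyl or nitrile, would serve as well. They also leave open how compound 3 would respond to an amine in place of its methylthio group.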